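The source may report more compounds than this note shows. Statements on the series, on what has been measured and on what is new or still open speak of the compounds shown alone.

Compound 1 `CC(C)(C)c1cn(C[C@H](O)[C@H]2OC(=O)C(OCc3ccccc3)=C2OCc2ccccc2)nn1` gives 730 nM in a functional assay on MCF7 cells (Homo sapiens) for antiproliferative activity, read by MTT assay, with a stated time of 72 h (on this read-out higher numbers stand for weaker inhibition and lower numbers for stronger inhibition), the lower of the two numbers recorded; compound 2 `O=C1O/C(=C\Cn2cc(-c3cccc(O)c3)nn2)C(OCc2ccccc2)=C1OCc1ccccc1` gives 27800 nM in this assay, a gap well beyond the scatter. Among the measured compounds shown here, no measured pair differs in a single place, so compound 3 `CCCCCc1ccc(-c2cn(C[C@H](O)[C@H]3OC(=O)C(OCc4ccccc4)=C3OCc3ccccc3)nn2)cc1` must be judged from the change itself: 4-pentylphenyl in place of tert-butyl on an aromatic carbon, the rest of the shared core left untouched. With nothing shown for this swap, a step of a 2.1-fold higher number from compound 1 to compound 3 (0.31 log units; beyond the scatter) of modest size is expected, its direction uncertain. Compound 3 is estimated at 1500 nM, within a range of 300 nM to 8000 nM.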

Compound 3, half-maximal inhibitory concentration: 9010 nM
The estimate for compound 3 lay 6.0-fold (0.78 log units) below the measured number, outside the stated range (above it).
By their numbers in this assay, from the lowest: compound 1; then compound 3; then compound 2.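

At this aromatic carbon of the five-membered aromatic ring, the first single-place change gives a clear loss in this assay: replacing tert-butyl with 4-pentylphenyl produces a 12-fold higher number from compound 1 to compound 3 (1.09 log units; beyond the scatter). The position is therefore sensitive to the group it carries, at least for this swap. Nothing available explains the weaker inhibition.

As far as these compounds go, it remains open whether the higher number goes with the added aromatic ring or with the pentyl chain. A plain phenyl group or a 4-methylphenyl group on the same carbon would separate the two.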